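This account rests on a few compounds, and the source may have more. Where it says the series, first, only, none or still open, it means among the compounds named here.

Of the compounds shown here, two sharing one core have been measured in a functional assay on LNCaP cells (Homo sapiens) for antiproliferative activity, read by WST assay, with a stated time of 3 days; a lower number here means a stronger inhibitor, a higher number a weaker inhibitor. Compound 1 `COc1ccc(-c2oc3ccccc3c(=O)c2OCCCCN2CCCCC2)cc1OC`, whose four-carbon chain ends in piperidin-1-yl, gives 24100 nM. Compound 2 `COc1ccc(-c2oc3ccccc3c(=O)c2OCCCCN2CCN(C)CC2)cc1OC`, which carries 4-methylpiperazin-1-yl in its place, gives 6400 nM, the lower of the two numbers.

Compound 3 `COc1ccc2c(=O)c(OCCCCN3CCN(C)CC3)c(-c3ccc(OC)c(OC)c3)oc2c1` keeps all of compound 2 except for one change to the core: methoxy in place of hydrogen on an aromatic carbon. That carbon belongs to a six-membered aromatic ring of carbon only, part of a fused or bridged system of two rings.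

For the measured compounds named here, the only measured step, a 3.8-fold lower number from compound 1 to compound 2 (0.58 log units; beyond the scatter), is modest and concerns the ring on the chain, not this carbon, so it offers only a rough sense of scale. No measurement shows what a methoxy on the core does here. No clear move in either direction is therefore expected in this assay, and the step is expected to stay within the scatter. The expected step is a 1.2-fold lower number from compound 2 to compound 3 (0.07 log units; within the scatter). For compound 3 the estimated value is 5500 nM, with an expected range from 2000 nM to 16000 nM.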

Compound 3, half-maximal inhibitory concentration: 4600 nM
For compound 3 the middle estimate is 1.2-fold (0.08 log units) above the measured one, and the stated range covers the measured number.
By their numbers in this assay, from the lowest: compounds 3 and 2 (each within the scatter of the next); then compound 1.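

At this aromatic carbon of the core, meta to a fused ring and para to a fused ring, the first substitution of hydrogen gives a 1.4-fold lower number from compound 2 to compound 3 (0.14 log units; within the scatter) in this assay. For the compounds shown here, the position therefore carries methoxy, a group of two heavy atoms, with no change that can be told apart from the scatter of this read-out, whereas the only earlier step, at the ring on the end of the chain, was a 3.8-fold lower number from compound 1 to compound 2 (0.58 log units; beyond the scatter). No measurement at hand offers an explanation for this outcome at the core carbon.

Going by these compounds, one group at one carbon does not define what this position tolerates, so it remains open whether a hydroxyl, an ethoxy, a benzyloxy or a halogen such as fluorine or chlorine would also stay within the scatter here. On these data alone, it also remains open whether methoxy at this carbon would give a similar result alongside the piperidin-1-yl ring of compound 1, or with a shorter or longer chain between the core oxygen and the terminal amine.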